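The source may report more compounds than this note shows. Statements on the series, on what has been measured and on what is new or still open speak of the compounds shown alone.

In a functional assay on PC-3 cells (Homo sapiens) for antiproliferative activity, read by MTT assay, with a stated time of 48 h (on this read-out higher numbers stand for weaker inhibition of growth and lower numbers for stronger inhibition of growth), compound 1 `CCOc1cc(NC(=O)CCCCCC(=O)Nc2cc(-c3ccccc3)ccc2N)cc2c1OCC([N+](=O)[O-])=C2` gives 7080 nM, compound 2 `CCOc1cc(NC(=O)CCCCCCC(=O)Nc2cc(-c3ccccc3)ccc2N)cc2c1OCC([N+](=O)[O-])=C2` gives 10700 nM, and compound 3 `CCOc1cc(NC(=O)CCCCCCC(=O)Nc2cc(-c3ccc(C)s3)ccc2N)cc2c1OCC([N+](=O)[O-])=C2` gives 6360 nM.

All three numbers lie within the usual scatter of one another, so no order among them is claimed. Compound 4 `CCOc1cc(NC(=O)CCCCCC(=O)Nc2cc(-c3ccc(C)s3)ccc2N)cc2c1OCC([N+](=O)[O-])=C2` has not yet been measured in this assay. The difference between the core of compound 1 and the core of compound 2 is not broken down here. Compound 3 differs from compound 2 in one place: 5-methylthiophen-2-yl in place of phenyl on an aromatic carbon That change gave a 1.7-fold lower number from compound 2 to compound 3 (0.23 log units; within the scatter). Compound 4 differs from compound 1 in the same place and in the same way: 5-methylthiophen-2-yl in place of phenyl on an aromatic carbon The change occurs twice among these four compounds, each time at the same position, so it is taken as the same change.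

The expectation for compound 4 rests on compound 1, which gives 7080 nM, shifted by about the size seen in a 1.7-fold lower number from compound 2 to compound 3 (0.23 log units; within the scatter). Compound 4 is therefore expected to give about 4500 nM, estimated to lie between 2200 nM and 9500 nM. Going by the values given here, for compound 4 the expected step is a 1.6-fold lower number from compound 1 to compound 4 (0.20 log units; within the scatter), which is estimated because a 1.7-fold lower number from compound 2 to compound 3 (0.23 log units; within the scatter) was the only prior instance of this change.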

Compound 4, concentration for 50% growth inhibition: 11400 nM
The estimate for compound 4 lay 2.5-fold (0.40 log units) below the measured number; measured number outside the range, above it.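

In this assay, putting 5-methylthiophen-2-yl in place of phenyl on the core of compound 1 gave a 1.6-fold higher number from compound 1 to compound 4 (0.21 log units; within the scatter), a step too small to count as a loss of growth inhibition when taken alone. Set beside the same change on the other core, however, it does not match the earlier step: the same change on two cores in this assay, a 1.7-fold lower number (0.23 log units; within the scatter) from compound 2 to compound 3 and a 1.6-fold higher number (0.21 log units; within the scatter) from compound 1 to compound 4, 2.7-fold (0.43 log units) apart, beyond the scatter of two such steps. Going by these compounds alone, this shows that, for these two pairs, the step seen on one core could not be carried to the other as a fixed shift, yet with only one pair on each core it does not show that either core favours one of the two groups, nor does it explain why the steps part.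

The compounds shown leave open how the same change would behave with a longer chain between the two amides, or with a shorter one. They also leave open whether a plain thiophen-2-yl or a pyridine ring in that place would follow the step of one core, the other, or neither.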